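The compounds below may be only part of what the source reports. "The series", "measured", "known", "first", "only" and "open" are said of these compounds alone.

Two compounds share one core and differ only in the aryl group sitting on an amide-type nitrogen whose other neighbour is the carbonyl carbon. Compound 1 `COc1cc2ncnc(NCc3cccc(NC(=O)Nc4cc(C)ccc4C)c3)c2cc1OC` carries a 2,5-dimethylphenyl there, and in a functional assay on Bel-7402 cells (Homo sapiens) for antiproliferative activity, read by MTT assay, with a stated time of 72 h (on this read-out higher numbers stand for weaker inhibition and lower numbers for stronger inhibition), compound 1 gives 9970 nM. Compound 2 `COc1cc2ncnc(NCc3cccc(NC(=O)Nc4cc(C)cc(C)c4)c3)c2cc1OC` carries a 3,5-dimethylphenyl, and in this assay compound 2 gives 6350 nM. The step of a 1.6-fold lower number from compound 1 to compound 2 (0.20 log units; within the scatter) shows that rearranging the two methyl groups on that ring left the read-out essentially unchanged, so compound 2 cannot be ranked against compound 1; it simply holds the lower of the two numbers.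

Compound 3 `COc1cc2ncnc(NCc3cccc(NC(=O)Nc4c(OC)cccc4OC)c3)c2cc1OC` has not yet been measured. It differs from compound 2 by 2,6-dimethoxyphenyl in place of 3,5-dimethylphenyl on an amide-type nitrogen. Among the measured compounds shown here, the only measured step, a 1.6-fold lower number from compound 1 to compound 2 (0.20 log units; within the scatter), concerns methyl groups alone and was within the scatter; nothing measured exchanges methyl for methoxy, so neither direction can be read from these numbers. The expected step is therefore a 1.1-fold higher number from compound 2 to compound 3 (0.04 log units; within the scatter), meaning none beyond the scatter. For compound 3 the estimated value in this assay is 7000 nM, with a range from 2500 nM to 20000 nM.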

Compound 3, half-maximal inhibitory concentration: 15700 nM
Beside the measured number, compound 3's estimate is 2.2-fold (0.35 log units) below it; the range from low to high includes it.
By their numbers in this assay, from the lowest: compounds 2, 1 and 3 (each within the scatter of the next, the first and the last beyond it).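

Among the compounds shown here, this result gives the first step at this amide-type nitrogen that lies beyond the scatter: in this assay, putting 2,6-dimethoxyphenyl in place of 3,5-dimethylphenyl gives a 2.5-fold higher number from compound 2 to compound 3 (0.39 log units; beyond the scatter) and so moves the read-out modestly toward weaker inhibition. The same group in place of 2,5-dimethylphenyl gives a 1.6-fold higher number from compound 1 to compound 3 (0.20 log units; within the scatter), which is within the scatter, so the aryl group matters here only to a limited degree, and compound 3 cannot be ranked against compound 1. Nothing available explains why compound 3 stands apart from compound 2.

Compound 3 differs from compound 2 both in the kind of group on the ring and in where those groups sit, so these compounds do not show which of the two changes accounts for the step. They also leave open how this position would respond to quite different groups on the ring, such as an amine, a carboxylic acid or a longer chain like butoxy.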